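Adding a Phenyl: Expected Effect on Microsomal Clearance

The source may hold more compounds than are shown below. What is called first, only, known or untested is meant among the compounds shown, and "the series" means these compounds.

Of the compounds shown here, two have been measured so far. Compound 1 `O=C1COC(c2ccccc2)=NN1c1ccccc1` and compound 2 `O=c1ccc(-c2ccccc2)cn1-c1ccccc1` are not linked by any single change, so only their numbers can be set side by side. In an in vitro ADME assay on microsomes from liver (Rattus norvegicus) for metabolic stability, read by LC-MS, with a stated time of 15 min (a higher number here means faster removal of the compound, a lower number slower removal), compound 1 gives 0.476 mL.min-1.g-1. In this assay compound 2 gives 0.486 mL.min-1.g-1. Compound 2 holds the higher of the two numbers, with compound 1 nearest, but the gap between them lies within the usual scatter, so the two readings cannot be told apart.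

Compound 3 `O=c1c(-c2ccccc2)cc(-c2ccccc2)cn1-c1ccccc1` has not yet been measured. It differs from compound 2 by one change: phenyl in place of hydrogen on an aromatic carbon. Among the measured compounds shown here, no measured pair shows what such a change does here, so the expectation rests only on compound 2, whose reading 0.486 mL.min-1.g-1 is the starting point. The expected step of a 1.7-fold higher number from compound 2 to compound 3 (0.24 log units; within the scatter) is a modest rise, only just beyond the scatter. Compound 3 is therefore estimated at 0.85 mL.min-1.g-1, with a likely range from 0.4 mL.min-1.g-1 to 1.8 mL.min-1.g-1.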

Compound 3, intrinsic clearance in microsomes: 0.052 mL.min-1.g-1
Compound 3: middle estimate off by 16-fold (1.21 log units), on the high side; the whole stated range lies above it.
By their numbers in this assay, from the lowest: compound 3; then compounds 1 and 2 (each within the scatter of the next).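

Phenyl in place of hydrogen on an aromatic carbon, ortho to a group of 1 heavy atom and two atoms from the ring nitrogen, gives in this assay a step of a 9.3-fold lower number from compound 2 to compound 3 (0.97 log units; beyond the scatter) and so moves the reading clearly beyond what repeated measurements would blur. Among the compounds shown here, compound 1 and compound 2 could only be set side by side, with readings that cannot be told apart, so this is the first single change on view, and it shows that this position of the shared core is not indifferent: a change here alone can bring a large fall in the number, meaning slower removal of the compound. Nothing available says why the number falls at this position.

One step at one position leaves open how much of the fall belongs to phenyl itself, since a methyl group, an amine or a carboxylic acid on the same aromatic carbon could give a quite different reading. Going by these compounds, it is also open whether phenyl on another carbon of the same ring would lower the number at all, and whether the same step would hold on the core of compound 1.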